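Chlorostyryl in Place of Difluorophenyl: an Expected Value

This account rests on a few compounds, and the source may have more. Where it says the series, first, only, none or still open, it means among the compounds named here.

Measured compounds:
compound 1, `CC(C)(C)Cc1c(-c2ccc(F)cc2F)sc(N)c1C(=O)c1ccc(Cl)cc1`: 1%
compound 2, `CC(C)(C)Cc1c(-c2cc(F)ccc2F)sc(N)c1C(=O)c1ccc(Cl)cc1`: 1%

In an assay on CHO cells for displacement of a labelled ligand from adenosine receptor A3 (Homo sapiens), read by scintillation counting, tested at 10 uM (a lower number here means less inhibition, a higher number more inhibition at the concentration tested (going by the name of the read-out)), compound 1 gives 1%, and compound 2 gives 1%. Among the measured compounds shown here, the single measured step, no change at the digits printed from compound 1 to compound 2 (within the scatter), came with a 2,5-difluorophenyl in place of a 2,4-difluorophenyl on an aromatic carbon. Compound 2 therefore stands level with compound 1 at the digits shown, and both lie at the bottom of the scale.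

Compound 3, `CC(C)(C)Cc1c(/C=C/c2ccc(Cl)cc2)sc(N)c1C(=O)c1ccc(Cl)cc1`, differs from compound 2 as follows: 2-(4-chlorophenyl)ethenyl in place of 2,5-difluorophenyl on an aromatic carbon. For the measured compounds named here, the only step in hand bears on compound 3 just indirectly, since it exchanged one difluorophenyl for another and produced no change beyond the scatter. With both measured compounds near zero, the expectation is a step of a number 4 percentage points higher from compound 2 to compound 3 (within the scatter), that is, none beyond the scatter in either direction. Compound 3 is estimated at 5%, with a range from 0% to 25%.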

Compound 3, a percentage reported as inhibition, at one concentration (the size of the read-out at that concentration, not a potency): 11%
Compound 3: middle estimate off by 6 percentage points, on the low side; the range from low to high includes it.
By their numbers in this assay, from the lowest: compounds 1, 2 and 3 (each within the scatter of the next).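

At this position, on the aromatic carbon next to the ring sulfur, the change is far larger than the earlier swap of one difluorophenyl for another, yet in this assay it gives a number 10 percentage points higher from compound 2 to compound 3 (within the scatter) and, against the other difluorophenyl compound, a number 10 percentage points higher from compound 1 to compound 3 (within the scatter) in the same read-out. The entering 2-(4-chlorophenyl)ethenyl brings a double bond outside the aromatic rings and a chlorine in place of two fluorines, and the three compounds still cannot be told apart. Nothing available gives a reason for this result.

From the compounds shown here alone, whether an amine or a carboxylic acid on the aromatic ring of this group would move the read-out beyond the scatter stays open. So does the part played by the neopentyl group and the (4-chlorophenyl)carbonyl group, which all three compounds share.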